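This account rests on a few compounds, and the source may have more. Where it says the series, first, only, none or still open, it means among the compounds named here.

Compound 1 `CCc1ccccc1NC(=O)N[C@@H](C)c1ccccc1`: 100% in an ADME assay on the whole organism with Oryza sativa as the target, tested at 0.1 uM; on this read-out higher numbers stand for a weaker effect at the one concentration tested and lower numbers for a stronger effect
Compound 2 `CCCc1ccc(NC(=O)N[C@H](C)c2ccccc2)cc1`: 33%
Compound 3 `CCCc1ccc(NC(=O)N[C@@H](C)c2ccccc2)cc1`: 97%
Compound 4 `CCCCCc1ccc(NC(=O)N[C@H](C)c2ccccc2)cc1`: not yet measured

Among the three measured compounds, compound 2 stands lowest in this assay, with compound 3 nearest to it and compound 1 furthest. Within the data shown here, the single step between compounds that differ in one place, a number 64 percentage points higher from compound 2 to compound 3 (beyond the scatter), goes with the fact that compounds 2 and 3 differ only in the configuration as drawn and changes no chain. Compound 4 differs from compound 2 by ethyl in place of hydrogen on a saturated chain carbon, three bonds along the chain from an aromatic carbon. Among the measured compounds shown here, no measured step changes a chain in this way, so none of them bears on this change, and no step beyond the scatter is assumed, though with wide uncertainty. Compound 4 is therefore expected to give about 45%, within 10% to 95%, which is an expected a number 12 percentage points higher from compound 2 to compound 4 (beyond the scatter).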

Compound 4, a percentage reported as activity, at one concentration (the size of the read-out at that concentration, not a potency): 100%
Beside the measured number, compound 4's estimate is 55 percentage points below it, outside the stated range (above it).
By their numbers in this assay, from the lowest: compound 2; then compounds 3, 1 and 4 (each within the scatter of the next).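

In this assay, ethyl in place of hydrogen on a saturated chain carbon, three bonds along the chain from an aromatic carbon, turns propyl to pentyl and gives a number 67 percentage points higher from compound 2 to compound 4 (beyond the scatter). This position therefore does not accept the longer chain while keeping the effect, which earlier depended visibly only on configuration, with a number 64 percentage points higher from compound 2 to compound 3 (beyond the scatter). Nothing at hand explains the loss from the longer chain. The compounds shown leave open whether a butyl chain already loses the effect, and whether an amine or a hydroxyl group at this carbon would fare as ethyl does.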